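The compounds below may be only part of what the source reports. "The series", "measured", "known", "first", "only" and "open" are said of these compounds alone.

Measured so far:
Compound 1 `N#C[Se]c1ccc(NC(=O)OCc2ccc([N+](=O)[O-])cc2)cc1` gives 71900 nM
Compound 2 `N#C[Se]c1ccc(NC(=O)OCc2ccccc2)cc1` gives 69100 nM
Compound 3 `CCCCOC(=O)Nc1ccc([Se][Se]c2ccc(NC(=O)OCCCC)cc2)cc1` gives 82400 nM

All three numbers come from a functional assay on HT-29 cells (Homo sapiens) for cytotoxicity, read by MTT assay, with a stated time of 72 h; on this read-out higher numbers stand for lower toxicity in this test and lower numbers for higher toxicity in this test. Compound 2 stands at the lowest of the three values, but its nearest neighbour, compound 1, lies at essentially the same level, and compound 3, the furthest, is also within the scatter, so no order among the three can be read. For the measured compounds named here, the one step of a single change, a 1.0-fold lower number from compound 1 to compound 2 (0.02 log units; within the scatter), shows that replacing the nitro group left the read-out unchanged.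

Compound 4 `CC(C)COC(=O)Nc1ccc([Se]C#N)cc1` differs from compound 2 by isopropyl in place of phenyl on a saturated chain carbon bound to an oxygen next to a carbonyl group. Going by the values given here, no measured step touches this position directly. The carbamate ester of compound 3 carries a butyl chain, and compound 3 gives 82400 nM, which sits close to compound 2; the other measured step was flat. On this basis he expects no step beyond the scatter, and the change a 1.1-fold higher number from compound 2 to compound 4 (0.04 log units; within the scatter) is estimated to be small. For compound 4 the expected value in this assay is 75000 nM, with a range from 35000 nM to 160000 nM.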

Compound 4, concentration lethal to 50% of the cells: 63700 nM
Compound 4: middle estimate off by 1.2-fold (0.07 log units), on the high side; the measured number falls inside the stated range.
By their numbers in this assay, from the lowest: compounds 4, 2, 1 and 3 (each within the scatter of the next).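

For the compounds shown here, this is the first direct step at this position, on a saturated chain carbon bound to an oxygen next to a carbonyl group, and in this assay the number barely moves, with a 1.1-fold lower number from compound 2 to compound 4 (0.04 log units; within the scatter). The earlier step changed only a substituent on the aromatic ring, whereas here the whole phenyl, with its six-membered aromatic ring, gives way to the smaller isopropyl with no ring, and the read-out stays level, so for this pair the aromatic ring at this place is not needed to hold the value. No other measurement shown here offers an explanation for this flat result.

From the compounds shown here alone, whether an amine or a carboxylic acid at this place would shift the number remains open. So does the effect of a longer chain, since no step shown so far lies beyond the scatter.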